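A few compounds are considered here, and "the series" means these few. Any claim that something is new, unique, unknown or untested is made for them only; others in the source may bear on it.

Measured compounds:
compound 1 `O=C(CN1CCC(c2cccc[n+]2[O-])CC1)NC1CCCCC1` — 58%
compound 2 `Cc1cccc(NC(=O)CN2CCC(c3ccccc3)CC2)c1` — 37%

Of the two compounds with numbers in a functional assay on HEK293 cells for agonist activity at D(4) dopamine receptor (Homo sapiens), read by FLIPR (a higher number here means a larger maximal response, a lower number a smaller maximal response), compound 1 has the higher one. Compound 2 sits lower by an amount that is beyond the usual scatter of this assay, but the two structures differ in more than one place, so nothing can be read from that pair about any single change.

Compound 3 `O=C(CN1CCC(c2cccc[n+]2[O-])CC1)Nc1ccccc1F` is the next compound for this assay. It differs from compound 1 in one place: 2-fluorophenyl in place of cyclohexyl on an amide-type nitrogen. Within the data shown here, no measured pair isolates this change, so its direction and size are open. The only anilide among the measured compounds, compound 2, gives a smaller maximal response than compound 1, yet it also carries a different group on the piperidine, so this is weak guidance at best.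

On that basis a step from compound 1 to compound 3 of a number 13 percentage points lower from compound 1 to compound 3 (beyond the scatter) is expected, a modest loss that may or may not exceed the scatter. For compound 3 the estimate in this assay is 45%, within a range of 25% to 65%.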

Compound 3, largest response reached (reported as efficacy), in percent of the reference or control that the assay uses: 63%
Estimate against measurement, compound 3: 18 percentage points below; low and high end bracket the measured number.
By their numbers in this assay, from the lowest: compound 2; then compounds 1 and 3 (each within the scatter of the next).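

In this assay, 2-fluorophenyl in place of cyclohexyl on the amide-type nitrogen gives a number 5 percentage points higher from compound 1 to compound 3 (within the scatter), so this single change does not separate the two groups on this read-out. With the rest of compound 1 held constant, the position accepts both a six-membered non-aromatic carbon ring and a six-membered aromatic carbon ring bearing fluorine, without a difference in maximal response that can be told from the scatter; this rests on one pair only and says nothing about other cores or other substituents. No measured property of these compounds is available to account for this outcome.

Still open, on these data alone, is what the fluorine contributes on its own, since plain phenyl on the same nitrogen would be needed to separate it from the change from a saturated to an aromatic ring. Also open, as far as these compounds go, is how far the position tolerates other kinds of group, such as benzyl, a longer alkyl chain, an amine or a carboxylic acid, and whether any of these would shift the maximal response beyond the scatter.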